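Extending a Methyl Group With a Dimethylamino Chain

A few compounds are considered here, and "the series" means these few. Any claim that something is new, unique, unknown or untested is made for them only; others in the source may bear on it.

Compound 1 `Cn1c(Cc2nn(C)c(=O)c3ccccc23)nnc1SCCCCCCCC(=O)Nc1ccc(Cl)cc1Cl` gives 3900 nM in an assay on 32D cells for inhibition of interleukin-15 (Mus musculus), read by resazurin assay, with stated times of 30 min and 2.5 days, in the presence of a further agent that is not named here (on this read-out lower numbers stand for stronger inhibition and higher numbers for weaker inhibition), the second highest of the three numbers measured. Compound 3 `Cn1nc(Cc2nnc(SCCCCCCCC(=O)Nc3ccc(Cl)cc3Cl)[nH]2)c2ccccc2c1=O` gives 3500 nM, and a 1.1-fold lower number from compound 1 to compound 3 (0.05 log units; within the scatter). Compound 2 `CCOC(CCn1c(Cc2nn(C)c(=O)c3ccccc23)nnc1SCCCCCCCC(=O)Nc1ccc(Cl)cc1Cl)OCC` gives 16400 nM, and a 4.2-fold higher number from compound 1 to compound 2 (0.62 log units; beyond the scatter). Compound 4 `CN(C)CCCn1nc(Cc2nnc(SCCCCCCCC(=O)Nc3ccc(Cl)cc3Cl)n2C)c2ccccc2c1=O` differs from compound 1 by 2-(dimethylamino)ethyl in place of hydrogen on a saturated chain carbon bound to an aromatic nitrogen. Among the measured compounds shown here, only the step from compound 1 to compound 2, which likewise adds a chain at a saturated chain carbon bound to an aromatic nitrogen, bears on this change; it was modest and weakening. A somewhat weaker result is therefore expected for compound 4, by a step of about a 1.8-fold higher number from compound 1 to compound 4 (0.25 log units; within the scatter), though the entering chain is of a different kind, so the range is kept wide. Compound 4 is estimated at 7000 nM, between 2500 nM and 25000 nM.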

Compound 4, half-maximal inhibitory concentration: 3200 nM
Compound 4: middle estimate off by 2.2-fold (0.34 log units), on the high side, within the range that was stated.
By their numbers in this assay, from the lowest: compounds 4, 3 and 1 (each within the scatter of the next); then compound 2.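

Here, a methyl on an aromatic nitrogen can grow into 3-(dimethylamino)propyl with no readable change in this assay (a 1.2-fold lower number from compound 1 to compound 4 (0.09 log units; within the scatter)). Compound 2 carries its added chain on a different aromatic nitrogen, so its weaker number does not describe this place. Nothing measured here explains why the chain is tolerated. On these data alone, whether a plain butyl chain or a chain ending in a carboxylic acid would behave the same way at this place remains open, as does the effect of a longer dimethylamino chain.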